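From an Ethyl Ester to a Difluorophenyl Ketone

A few compounds are considered here, and "the series" means these few. Any claim that something is new, unique, unknown or untested is made for them only; others in the source may bear on it.

Measured compounds:
- compound 1, `CCOC(=O)/C=C1/C(=O)N2[C@@H]1SC(C)(C)[C@@H]2C(=O)OC(c1ccccc1)c1ccccc1`: 11200 nM
- compound 2, `CC1(C)[C@H](C(=O)OC(c2ccccc2)c2ccccc2)N2C(=O)/C(=C/C(=O)c3ccc([N+](=O)[O-])cc3)[C@H]2S1(=O)=O`: 95500 nM

In a functional assay on OE19 cells (Homo sapiens) for cytotoxicity, read by MTT assay, with a stated time of 48 h (a higher number here means a weaker inhibitor, a lower number a stronger inhibitor), compound 1 gives 11200 nM, the lower of the two numbers; the gap to compound 2 lies beyond the usual scatter. Compound 2 differs from compound 1 in more than one place, so no single step can be read from that pair. Compound 3, `CC1(C)S[C@@H]2/C(=C\C(=O)c3cc(F)cc(F)c3)C(=O)N2[C@H]1C(=O)OC(c1ccccc1)c1ccccc1`, differs from compound 1 by 3,5-difluorophenyl in place of ethoxy on a carbonyl carbon. Only the weaker number of compound 2 hints at a ketone of this kind, so a modest rise in number is expected, a 1.8-fold higher number from compound 1 to compound 3 (0.25 log units; within the scatter). Compound 3 is estimated at 20000 nM, within 5000 nM to 80000 nM.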

Compound 3, half-maximal inhibitory concentration: 17600 nM
Compound 3: middle estimate off by 1.1-fold (0.06 log units), on the high side; low and high end bracket the measured number.
By their numbers in this assay, from the lowest: compounds 1 and 3 (each within the scatter of the next); then compound 2.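

In this assay, 3,5-difluorophenyl in place of ethoxy on a carbonyl carbon gives a 1.6-fold higher number from compound 1 to compound 3 (0.20 log units; within the scatter) and so leaves the two compounds level. This position therefore takes a six-membered aromatic ring in place of a small ethoxy group, turning an ester into a ketone, with no shift beyond the scatter.

From the compounds shown here alone, whether an amine, a carboxylic acid or a longer chain on this carbonyl carbon would read differently stays open, as does whether plain phenyl would match 3,5-difluorophenyl. No measurement shown explains the result.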